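The source may hold more compounds than are shown below. What is called first, only, known or untested is meant among the compounds shown, and "the series" means these compounds.

Compound 1 `CCOC(=O)c1nc2ccccc2nc1C#Cc1ccccc1C` gives 27000 nM in a functional assay on A549 cells (Homo sapiens) for antiproliferative activity, read by MTT assay, with a stated time of 72 h (on this read-out lower numbers stand for stronger inhibition and higher numbers for weaker inhibition), the higher of the two numbers recorded, while compound 2 `CCOC(=O)c1nc2ccccc2nc1C#Cc1ccc(C)cc1` gives 3300 nM. For the measured compounds named here, the only measured step, an 8.2-fold lower number from compound 1 to compound 2 (0.91 log units; beyond the scatter), changes the same group that compound 3 `CCOC(=O)c1nc2ccccc2nc1C#CC1CCCC1` alters: cyclopentyl in place of 2-methylphenyl on a triple-bonded carbon. That step bears only loosely on this exchange, since a non-aromatic ring replaces the aromatic one rather than moving the methyl. A small improvement is therefore expected, with compound 3 estimated at 15000 nM, within 4000 nM to 50000 nM. This expectation corresponds to a 1.8-fold lower number from compound 1 to compound 3 (0.26 log units; within the scatter).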

Compound 3, half-maximal inhibitory concentration: 11200 nM
Compound 3: middle estimate off by 1.3-fold (0.13 log units), on the high side, within the range that was stated.
By their numbers in this assay, from the lowest: compound 2; then compound 3; then compound 1.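

An aromatic ring on this triple-bonded carbon is not needed for a measurable effect in this assay, since cyclopentyl in place of 2-methylphenyl gives a lower number (a 2.4-fold lower number from compound 1 to compound 3 (0.38 log units; beyond the scatter)). Cyclopentyl in place of 4-methylphenyl instead gives a higher number (a 3.4-fold higher number from compound 2 to compound 3 (0.53 log units; beyond the scatter)), so the direction of this exchange depends on which methylphenyl group leaves. No supporting data explain this difference.

On these data alone, it remains open how an open-chain group such as n-butyl would behave on this triple-bonded carbon. The same is true of a group carrying an amine or a hydroxyl.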